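The compounds below may be only part of what the source reports. "The series", "measured", "known", "first", "only" and "open" are said of these compounds alone.

Series read in a functional assay on the whole organism (Tail, strain ICR) with Mus musculus as the target, in the tail flick test, with a stated time of 60 min, at a dose of 25 umol/kg by the oral route; on this read-out lower numbers stand for a weaker effect and higher numbers for a stronger effect at the one dose given; measured so far:

compound 1, `C[C@@H](O)[C@H](NC(=O)CN(c1nc(Cl)nc2[nH]cnc12)C1CC1)C(=O)O`: 30.1%
compound 2, `NCCCC[C@H](NC(=O)CN(c1nc(Cl)nc2[nH]cnc12)C1CC1)C(=O)OCc1ccccc1`: 41.2%
compound 3, `CC(C)[C@H](NC(=O)CN(c1ncnc2c1ncn2C1CCCCO1)C1CC1)C(=O)OCc1ccccc1`: 34.9%

Compound 1 gives the smallest of the three numbers in this assay. Its nearest neighbour is compound 3, and the gap between them lies within the scatter, so no order between compound 1 and compound 3 is claimed. The gap to compound 2 lies beyond the scatter, so compound 2 does stand higher than compound 1 in this assay. Among the measured compounds shown here, no two of the measured compounds differ in only one place, so no single structural step has a measured size in this set.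

Compound 4, `NC(=O)CC[C@H](NC(=O)CN(c1nc(Cl)nc2[nH]cnc12)C1CC1)C(=O)O`, is the next compound for this assay. It differs from compound 1 as follows: 2-carbamoylethyl in place of 1-hydroxyethyl on a saturated chain carbon bound to an amide-type nitrogen and a carbonyl carbon. For the measured compounds named here, nothing among the measured compounds speaks to this particular change, and the three numbers in hand span a fairly narrow band. The step of a number 1.9 percentage points higher from compound 1 to compound 4 (within the scatter) is therefore expected to be small, with no direction beyond the scatter. Compound 4 is expected to give about 32% in this assay, with a range from 15% to 50%.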

Compound 4, a percentage reported as activity, at one dose (the size of the read-out at that dose, not a potency): 38.4%
Compound 4: the middle estimate sits 6.4 percentage points below what was measured; the measured number falls inside the stated range.
By their numbers in this assay, from the lowest: compounds 1, 3, 4 and 2 (each within the scatter of the next, the first and the last beyond it).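

In this assay, among the compounds shown here, 2-carbamoylethyl in place of 1-hydroxyethyl on a saturated chain carbon bound to an amide-type nitrogen and a carbonyl carbon gives a number 8.3 percentage points higher from compound 1 to compound 4 (within the scatter), the first step with a measured size at this position. This position therefore accepts the larger chain of five heavy atoms in place of three, and the defined stereocentre of 1-hydroxyethyl can be lost, without a shift beyond the scatter at this one dose. Nothing at hand offers an explanation for the size of this step.

From the compounds shown here alone, whether a carboxylic acid in place of the terminal carbamoyl, or a longer chain ending in an amine, would move the number beyond the scatter stays open. One step also leaves open whether any group at this position separates clearly from 1-hydroxyethyl.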